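A few compounds are considered here, and "the series" means these few. Any claim that something is new, unique, unknown or untested is made for them only; others in the source may bear on it.

Compound 1 `CC(C)(C)c1cc(NC(=O)Nc2ccc(-c3cn4ccccc4n3)cc2)no1` gives 3.09 nM in a functional assay on MV4-11 cells (Homo sapiens) for cytotoxicity, read by MTT assay, with a stated time of 72 h; a higher number here means a weaker inhibitor, a lower number a stronger inhibitor. For the measured compounds named here, compound 2 `CC(C)(C)c1cc(NC(=O)Nc2ccc(-c3cn4c(Cl)cccc4n3)cc2)no1` gives 56.1 nM in this assay, the higher of the two numbers, and an 18-fold higher number from compound 1 to compound 2 (1.26 log units; beyond the scatter) is the only measured step. Compound 3 `Cc1cccc2nc(-c3ccc(NC(=O)Nc4cc(C(C)(C)C)on4)cc3)cn12` differs from compound 2 by methyl in place of chloro on an aromatic carbon. Going by the values given here, no measured step swaps chloro for methyl; the sharp rise seen in an 18-fold higher number from compound 1 to compound 2 (1.26 log units; beyond the scatter) on placing one heavy atom at this spot suggests another single heavy atom there will behave much like chloro. For this change the expected step is a 1.4-fold lower number from compound 2 to compound 3 (0.15 log units; within the scatter), within the scatter. Compound 3 is estimated at 40 nM, between 10 nM and 160 nM.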

Compound 3, half-maximal inhibitory concentration: 20.2 nM
Estimate against measurement, compound 3: 2.0-fold (0.30 log units) above, within the range that was stated.
By their numbers in this assay, from the lowest: compound 1; then compound 3; then compound 2.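

A step of a 2.8-fold lower number from compound 2 to compound 3 (0.44 log units; beyond the scatter) on swapping chloro for methyl shows that two groups of one heavy atom each are not interchangeable at this spot in this assay. Methyl still gives a weaker inhibitor than hydrogen, with a 6.5-fold higher number from compound 1 to compound 3 (0.82 log units; beyond the scatter) for that change, so neither group matches the unsubstituted compound 1. Nothing measured here explains the gap between chloro and methyl. Still open, going by these compounds, is whether fluoro, an amine or a longer chain such as ethyl could match hydrogen at this spot. The same order on other carbons of this ring is also unknown.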